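Adding a fluoro group to the phenyl of compound 3

The source may report more compounds than this note shows. Statements on the series, on what has been measured and on what is new or still open speak of the compounds shown alone.

In a physicochemical assay for solubility, at pH 6.8 (on this read-out higher numbers stand for higher solubility and lower numbers for lower solubility), compound 1 `C[C@H](NC(=O)CC(F)(F)F)c1ccc(NC(=O)[C@H]2C[C@@H]2c2cccnc2)cc1` gives 41000 nM and compound 2 `C[C@H](NC(=O)[C@@H]1CCCN1C)c1ccc(NC(=O)[C@H]2C[C@@H]2c2cccnc2)cc1` gives 730000 nM. Compound 3 `C[C@H](NC(=O)c1ccccc1)c1ccc(NC(=O)[C@H]2C[C@@H]2c2cccnc2)cc1` returns only a limit, < 4000 nM, and not a number. On the numbers shown, compound 3 stands at the limit of < 4000 nM in this assay, at which 1 of the 3 values shown sits.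

Compound 4 `C[C@H](NC(=O)c1ccc(F)cc1)c1ccc(NC(=O)[C@H]2C[C@@H]2c2cccnc2)cc1` differs from compound 3 by a single change, fluoro in place of hydrogen on an aromatic carbon, para to a large group, turning phenyl into 4-fluorophenyl. For the measured compounds named here, two measured steps bear on it, and both exchange the whole group on the carbonyl carbon. Phenyl in place of 2,2,2-trifluoroethyl gave an at least 10-fold lower number from compound 1 to compound 3 (1.01 log units; beyond the scatter), and phenyl in place of 1-methylpyrrolidin-2-yl gave an at least 180-fold lower number from compound 2 to compound 3 (2.26 log units; beyond the scatter). Both were large, but neither measures a fluoro group on the phenyl ring, so the far smaller change is expected to give no step beyond the scatter in this assay, and another limit is likely. The expected step is a step that the limit leaves unreadable from compound 3 to compound 4. For compound 4 the estimate is 2500 nM, with an expected range of 1000 nM to 6000 nM.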

Compound 4, solubility: 6000 nM
For compound 4 the middle estimate is 2.4-fold (0.38 log units) below the measured one; measured number inside the range.
By their numbers in this assay, from the lowest: compound 4; then compound 1; then compound 2. At a limit, below all of these: compound 3.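

In this assay compound 4 gives a number, not a limit, for an aromatic ring on this carbonyl carbon, and it sets that ring against the two other groups: 4-fluorophenyl in place of 1-methylpyrrolidin-2-yl gave a 120-fold lower number from compound 2 to compound 4 (2.09 log units; beyond the scatter), and 4-fluorophenyl in place of 2,2,2-trifluoroethyl gave a 6.8-fold lower number from compound 1 to compound 4 (0.83 log units; beyond the scatter). For the fluoro group itself, the reading is an at least 1.5-fold higher number from compound 3 to compound 4 (0.17 log units; that floor lies within the scatter). That step stays a floor and its true size cannot be stated, because compound 3 has no number of its own: the limit of < 4000 nM in this assay, at which 1 of the 4 values shown sits.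

What the compounds shown leave open is whether an amine or a carboxylic acid on the same ring would bring the number closer to that of compound 2. Also open, going by these compounds, is how a fluoro group would read at another place on the ring.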